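Series notes: piperidinyl in place of thiazolyl on the shared core

The source may report more compounds than this note shows. Statements on the series, on what has been measured and on what is new or still open speak of the compounds shown alone.

Compound 1 `O=C(NCCCCc1ccccc1)n1cc(-c2nccs2)oc1=O` and compound 2 `O=C(NCCCCc1ccccc1)n1cc(-c2cscn2)oc1=O` share one core and differ only in the aromatic substituent. In an assay on isolated protein for inhibition of acid ceramidase (Homo sapiens), read by LC-MS, with a stated time of 1 h (a higher number here means a weaker inhibitor, a lower number a stronger inhibitor), compound 1 gives 59 nM, and compound 2 gives 44 nM. The step of a 1.3-fold lower number from compound 1 to compound 2 (0.13 log units; within the scatter) lies within the scatter, so the two thiazolyl isomers cannot be separated on these numbers. Compound 2 holds the lowest of the two values, with compound 1 as its nearest neighbour.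

Compound 3 `CN1CCC(c2cn(C(=O)NCCCCc3ccccc3)c(=O)o2)CC1` differs from compound 2 by 1-methylpiperidin-4-yl in place of 1,3-thiazol-4-yl on an aromatic carbon. Among the compounds with values here, no measured step bears on this change: the single step recorded in this assay exchanges one thiazolyl for another and says nothing about a non-aromatic group at this position. The data therefore leave the direction open; a weakening beyond the scatter is expected, with wide uncertainty. Compound 3 is expected to give 250 nM in this assay, within 50 nM to 1500 nM. The estimated step is a 5.7-fold higher number from compound 2 to compound 3 (0.75 log units; beyond the scatter).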

Compound 3, half-maximal inhibitory concentration: 1400 nM
Beside the measured number, compound 3's estimate is 5.6-fold (0.75 log units) below it, within the range that was stated.
By their numbers in this assay, from the lowest: compounds 2 and 1 (each within the scatter of the next); then compound 3.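

In this assay, the position on the aromatic carbon next to the ring oxygen proves sensitive to the group it carries: the exchange between the two thiazolyl isomers stayed within the scatter, whereas 1-methylpiperidin-4-yl gives a 32-fold higher number from compound 2 to compound 3 (1.50 log units; beyond the scatter) and a 24-fold higher number from compound 1 to compound 3 (1.38 log units; beyond the scatter), both large. This single change replaces a five-membered aromatic ring with a six-membered non-aromatic ring and also alters the heavy-atom count and the hetero atoms, so the steps cannot be assigned to any one of these differences. No measurement is available that would explain the weakening.

The compounds shown leave open which of these differences carries the weakening. A phenyl ring, a cyclohexyl ring or a piperidin-4-yl group without the methyl at this position would help to separate them.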